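Amide nitrogen substituent swap in a series of inactive compounds

This account rests on a few compounds, and the source may have more. Where it says the series, first, only, none or still open, it means among the compounds named here.

Working notes. The shared core carries an amide whose nitrogen substituent varies across the set, while the aryl group on the core also changes. Compound 1 `C=CC1=C(C(=O)NCCCCC)C(c2ccc(Cl)c(Cl)c2)OC1` bears a pentyl group on the amide nitrogen. In a functional assay on HeLa cells (Homo sapiens) for cytotoxicity, read by MTT assay, with a stated time of 24 h (a lower number here means a stronger inhibitor, a higher number a weaker inhibitor), compound 1 gives > 100000 nM, which is a limit of the assay rather than a number. Compound 2 `C=CC1=C(C(=O)NCc2ccc(Cl)cc2)C(c2ccc(F)cc2)OC1` returns > 100000 nM in this assay, again a limit. Compound 3 `C=CC1=C(C(=O)Nc2ccc(OCC)cc2)C(c2ccc(OC)cc2)OC1` likewise reaches only > 100000 nM in this assay, a limit once more. Among the compounds with values here, compound 1 therefore stands at the limit of > 100000 nM in this assay, at which 3 of the 3 values shown sit, alongside the other two, and no step between measured compounds can be sized from these data.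

Compound 4 `C=CC1=C(C(=O)NC(C)(C)C)C(c2ccc(Cl)c(Cl)c2)OC1` differs from compound 1 by tert-butyl in place of pentyl on an amide-type nitrogen, so the carbon count on the amide nitrogen drops by one while the aryl group is unchanged. With nothing but limits in hand for compound 1 and its neighbours, no step beyond the scatter is expected in this assay, and the most likely outcome for compound 4 is a further limit. The expected step is a step that the limit leaves unreadable from compound 1 to compound 4, none beyond the scatter. Compound 4 is estimated at 150000 nM in this assay, with a range from 50000 nM to 500000 nM.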

Compound 4, half-maximal inhibitory concentration: > 100000 nM
Compound 4 gave a limit, no number; the forecaster's own chance of this, stated with the estimate: 85%; the middle value is on the limit's open side.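

In this assay compound 4 gives > 100000 nM, a limit and not a number. Compound 1 and compound 4 both rest on limits, so no step between them can be read: the limit of > 100000 nM in this assay, at which 4 of the 4 values shown sit.

The compounds shown leave open whether any amide nitrogen substituent or aryl group on the shared core gives a measurable value in this assay.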